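Swapping Fluoro for Methoxy on the Fused Ring

A few compounds are considered here, and "the series" means these few. Any claim that something is new, unique, unknown or untested is made for them only; others in the source may bear on it.

Measured so far:
compound 1, `Cc1ccc(C(=O)Nc2cccc3cccnc23)cn1`
compound 2, `Cc1cnc(C(=O)Nc2cc(F)cc3cccnc23)cn1`
compound 3, `O=C(Nc1cc(F)cc2cccnc12)c1cnccn1`

In a functional assay on PANC-1 cells (Homo sapiens) for inhibition, read by MTT assay, with a stated time of 72 h (a higher number here means a weaker inhibitor, a lower number a stronger inhibitor), compound 1 gives > 10000 nM, and this is a limit of the assay rather than a number. In this assay compound 2 gives 2100 nM. In this assay compound 3 gives 670 nM, the lowest of the two numbers; the nearest is compound 2, reached by a 3.1-fold lower number from compound 2 to compound 3 (0.50 log units; beyond the scatter), a change of hydrogen in place of methyl on an aromatic carbon.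

The unmeasured compound 4, `COc1cc(NC(=O)c2cnccn2)c2ncccc2c1`, differs from compound 3 by methoxy in place of fluoro on an aromatic carbon. Going by the values given here, no measured step touches this position or this pair of groups: the only step measured, a 3.1-fold lower number from compound 2 to compound 3 (0.50 log units; beyond the scatter), concerns a methyl on the other ring, and the limit of > 10000 nM in this assay, at which 1 of the 3 values shown sits, for compound 1 sits on a compound that also lacks the fluoro. So nothing here says which way a methoxy in place of fluoro will move the number, and the expectation is a step that may well stay within the scatter.

Compound 4 is therefore estimated at 1000 nM, between 300 nM and 4000 nM, which means an expected step of a 1.5-fold higher number from compound 3 to compound 4 (0.17 log units; within the scatter) from compound 3 to compound 4.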

Compound 4, half-maximal inhibitory concentration: 2170 nM
For compound 4 the middle estimate is 2.2-fold (0.34 log units) below the measured one; low and high end bracket the measured number.
By their numbers in this assay, from the lowest: compound 3; then compounds 2 and 4 (each within the scatter of the next). At a limit, above all of these: compound 1.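

In this assay, putting methoxy in place of fluoro on this aromatic carbon gives a 3.2-fold higher number from compound 3 to compound 4 (0.51 log units; beyond the scatter), a modest step but one beyond the scatter, so the number does respond to what sits at this position. Going by these compounds alone, the earlier measured step concerned only a methyl on the other ring, so this is the first measured sign that the six-membered aromatic ring of carbon only, part of the fused system, also affects the number, and for this pair fluoro gives the lower number. Methoxy differs from fluoro in its heavy atoms and in carrying a hydrogen-bond acceptor, but no measurement shown gives a reason for the step or says which of these differences counts.

On these data alone, it remains open whether an amine, a chlorine or a longer chain such as ethoxy on this carbon would give a number closer to that of compound 3 or of compound 4. As far as these compounds go, this is also a single pair, so it is unknown whether the same swap would move the number the same way in a compound with a methyl on the other ring.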